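Swapping furan for pyrrole on a fused core

This account rests on a few compounds, and the source may have more. Where it says the series, first, only, none or still open, it means among the compounds named here.

Measured so far:
compound 1 `Cc1occc1-c1nnc2n1NC(c1ccco1)S2`, 21.6%
compound 2 `COc1ccc(Cc2nnc3n2NC(c2ccc([N+](=O)[O-])o2)S3)cc1OC`, 17.6%
compound 3 `Cc1occc1-c1nnc2n1NC(c1ccc([N+](=O)[O-])o1)S2`, 18.1%

All three were tested in a functional assay on the whole organism (strain Wistar Albino) for inhibition, with Rattus norvegicus as the target, read by paw edema, with a stated time of 2 h, at a dose of 20 mg/kg; on this read-out higher numbers stand for more inhibition at the one dose given (going by the name of the read-out) and lower numbers for less inhibition. Compound 1 holds the top number of the three, yet its gaps to compound 3 and compound 2 both lie within the scatter, so the three cannot be told apart. Compound 4 `Cc1occc1-c1nnc2n1NC(c1ccc[nH]1)S2` differs from compound 1 in one place: 1H-pyrrol-2-yl in place of furan-2-yl on a saturated ring carbon. Going by the values given here, no measured step touches this swap; the only step on record, a number 3.5 percentage points lower from compound 1 to compound 3 (within the scatter), concerns a different change and stayed within the scatter. With nothing pointing either way, no shift beyond the scatter is expected from compound 1 to compound 4, so that a number 0.6 percentage points lower from compound 1 to compound 4 (within the scatter) is estimated. Compound 4 is therefore expected to give about 21%, roughly between 10% and 32%.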

Compound 4, a percentage reported as inhibition, in the whole organism at one dose (the size of the read-out at that dose, not a potency): 18.2%
Estimate against measurement, compound 4: 2.8 percentage points above; the measured number falls inside the stated range.
By their numbers in this assay, from the lowest: compounds 2, 3, 4 and 1 (each within the scatter of the next).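

In this assay the swap gives a number 3.4 percentage points lower from compound 1 to compound 4 (within the scatter), so on this saturated ring carbon 1H-pyrrol-2-yl cannot be told apart from furan-2-yl, although their counts of hydrogen-bond donors and acceptors differ. Unlike the earlier step, which added nitro to the furan-2-yl ring, this one replaces the ring itself. No measurement here explains the result or ties it to a property of either ring.

From the compounds shown here alone, whether a phenyl ring or an amine on this carbon would move the number beyond the scatter remains open.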